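Thiocarbamate amides: from compound 3 to compound 4

The compounds below may be only part of what the source reports. "The series", "measured", "known", "first", "only" and "open" are said of these compounds alone.

Three benzamides sharing one core have been measured in a functional assay on HeLa cells (Homo sapiens) for antiproliferative activity, read by CCK-8 assay, with a stated time of 72 h, tested at 2 uM; a lower number here means a weaker effect, a higher number a stronger effect of the compound at the concentration tested. Compound 1 `COc1ccc(N2CCN(C(=S)SCc3ccc(C(=O)Nc4ccccc4N)cc3)CC2)cc1` gives 39.4% in this assay. Compound 2 `Nc1ccccc1NC(=O)c1ccc(CSC(=S)N2CCCc3ccccc32)cc1` gives 26.1%. Compound 3 `CCN(Cc1ccncc1)C(=S)SCc1ccc(C(=O)Nc2ccccc2N)cc1` gives 63.5%, the highest of the three numbers; the gaps to compound 1 and to compound 2 both lie beyond the scatter.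

Going by the values given here, only one step between measured compounds changes a single place: a number 37.4 percentage points higher from compound 2 to compound 3 (beyond the scatter). This swaps the whole amine on the thiocarbonyl carbon, so it shows that the amine group can move the read-out strongly, but says nothing directly about small changes within an open-chain amine.

Compound 4 `CN(Cc1cccnc1)C(=S)SCc1ccc(C(=O)Nc2ccccc2N)cc1` is not yet measured. It differs from compound 3 as follows: methyl((pyridin-3-yl)methyl)amino in place of ethyl((pyridin-4-yl)methyl)amino on a thiocarbonyl carbon. Both amines are open-chain and carry a pyridinylmethyl arm, so a step much smaller than a number 37.4 percentage points higher from compound 2 to compound 3 (beyond the scatter) is expected in this assay, likely within or only just beyond the scatter, and with no clear direction. The expected step is a number 8.5 percentage points lower from compound 3 to compound 4 (within the scatter). Compound 4 is therefore estimated at 55%, with a range from 35% to 75%.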

Compound 4, a percentage reported as inhibition, at one concentration (the size of the read-out at that concentration, not a potency): 16.4%
For compound 4 the middle estimate is 38.6 percentage points above the measured one; measured number outside the range, below it.
By their numbers in this assay, from the lowest: compounds 4 and 2 (each within the scatter of the next); then compound 1; then compound 3.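

In this assay, an open-chain amine with a pyridinylmethyl arm on the thiocarbonyl carbon does not by itself secure a high read-out: a number 47.1 percentage points lower from compound 3 to compound 4 (beyond the scatter) is a large drop from a change much smaller than the swap of a whole amine. With a number 9.7 percentage points lower from compound 2 to compound 4 (within the scatter) inside the scatter, methyl((pyridin-3-yl)methyl)amino cannot be told apart from 1,2,3,4-tetrahydroquinolin-1-yl at this position, so a small edit within the amine can cancel the whole gain seen in compound 3. Nothing at hand bears on the reason for this drop.

The step joins two edits, ethyl to methyl and pyridin-4-yl to pyridin-3-yl, so their shares cannot be separated. Ethyl((pyridin-3-yl)methyl)amino and methyl((pyridin-4-yl)methyl)amino would each carry only one of these edits, and the compounds shown include neither.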